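Hydrogen in place of benzyl at the assay limit

The compounds below may be only part of what the source reports. "The series", "measured", "known", "first", "only" and "open" are said of these compounds alone.

Compound 1 `CCCCC(CCO)n1cnc2c(Cl)ncnc21`: > 50000 nM, a limit
Compound 2 `CCCCCC(CCO)n1cnc2c(Cl)ncnc21`: > 50000 nM, a limit
Compound 3 `OCCC(COCc1ccccc1)n1cnc2c(Cl)ncnc21`: > 50000 nM, a limit

All three compounds were tested in a functional assay on HCT-116 cells (Homo sapiens) for antiproliferative activity, read by MTT assay, with a stated time of 48 h; a lower number here means a stronger inhibitor, a higher number a weaker inhibitor. Compound 3 gives > 50000 nM, which is a limit and not a number. The other two measured compounds also give only limits, so the whole series rests on one mark: the limit of > 50000 nM in this assay, at which 3 of the 3 values shown sit.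

Compound 4 `OCCC(CO)n1cnc2c(Cl)ncnc21` has not yet been measured. It departs from compound 3 by one change, (hydrogen in place of benzyl on an oxygen on a saturated carbon), which puts hydrogen in place of benzyl on an oxygen on a saturated carbon.

Among the measured compounds shown here, the only measured step is a step that the two limits leave unreadable from compound 1 to compound 2. That step concerns a methyl on a saturated chain carbon rather than a benzyl, and its size cannot be read, so it gives no measure for this change. For the measured compounds named here, no measured compound in this assay has yet given a number, so neither a size nor a direction can be drawn from the data, and no step beyond the scatter is expected. The expected step is a step that the limit leaves unreadable from compound 3 to compound 4, with no direction estimated for it. Another report of a limit is the likeliest outcome. For compound 4 the estimated value is 70000 nM, with an expected range from 25000 nM to 200000 nM.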

Compound 4, half-maximal inhibitory concentration: > 50000 nM
Compound 4: no number, only a limit; the forecaster's own chance of this, stated with the estimate: 85%; the middle value lies beyond the limit too.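

In this assay compound 4 gives > 50000 nM, which is a limit and not a number. No step can be read from compound 1, compound 2 or compound 3 to compound 4, since all four compounds stand at one mark: the limit of > 50000 nM in this assay, at which 4 of the 4 values shown sit.

The compounds shown leave open whether hydrogen in place of benzyl, or any other change among them, alters the result in this assay at all.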